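This account rests on a few compounds, and the source may have more. Where it says the series, first, only, none or still open, it means among the compounds named here.

Measured so far:
compound 1 `CCC(=O)N1CCC(CN(C2Cc3cc(C#N)ccc3N(Cc3cncn3C)C2)S(=O)(=O)c2ccccn2)CC1` gives 0.5 10^-6 cm/s
compound 2 `Cn1cncc1CN1CC(N(CC2CCN(C(=O)CC(F)(F)F)CC2)S(=O)(=O)c2ccccn2)Cc2cc(C#N)ccc21` gives 0.5 10^-6 cm/s
compound 3 `C=C(C)C(=O)N1CCC(CN(C2Cc3cc(C#N)ccc3N(Cc3cncn3C)C2)S(=O)(=O)c2ccccn2)CC1` gives 0.5 10^-6 cm/s

All three were run in an ADME assay on Caco-2 cells (Homo sapiens) for permeability, in the apical to basolateral direction; on this read-out higher numbers stand for higher permeability and lower numbers for lower permeability. Compound 3 stands level with compounds 1 and 2 at the digits printed; its nearest neighbour on these numbers is compound 1, its furthest compound 2, and both gaps lie within the scatter. The three steps among them, no change at the digits printed from compound 1 to compound 2 (within the scatter), no change at the digits printed from compound 1 to compound 3 (within the scatter) and no change at the digits printed from compound 2 to compound 3 (within the scatter), each exchanged the group on the carbonyl carbon of the amide without moving the read-out beyond the scatter.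

Compound 4 `Cn1cncc1CN1CC(N(CC2CCN(S(=O)(=O)c3ccccc3)CC2)S(=O)(=O)c2ccccn2)Cc2cc(C#N)ccc21` differs from compound 3 by phenylsulfonyl in place of (1-methylethenyl)carbonyl on an amine nitrogen in a ring. For the measured compounds named here, none of the measured steps touches this change directly: each of them kept the carbonyl and varied only what sits on it, whereas here the whole (1-methylethenyl)carbonyl leaves and a phenylsulfonyl enters on the amine nitrogen in the ring. Going by the values given here, the measured steps therefore give no direct precedent, only the observation that the shared core has so far held the same low value under every variation at this position.

On that basis compound 4 is expected to stay near the others, with a step of no change at the digits printed from compound 3 to compound 4 (within the scatter) that does not exceed the scatter. The estimate for compound 4 in this assay is 0.5 10^-6 cm/s, within a range from 0.2 10^-6 cm/s to 1.5 10^-6 cm/s.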

Compound 4, apparent permeability: 0.1 10^-6 cm/s
Estimate against measurement, compound 4: 5.0-fold (0.70 log units) above; the measured number lies below the stated range.
By their numbers in this assay, from the lowest: compound 4; then compounds 1, 2 and 3 (each within the scatter of the next).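

In this assay the substituent on the amine nitrogen in the ring now makes a measurable difference, with a 5.0-fold lower number from compound 3 to compound 4 (0.70 log units; beyond the scatter), a 5.0-fold lower number from compound 2 to compound 4 (0.70 log units; beyond the scatter) and a 5.0-fold lower number from compound 1 to compound 4 (0.70 log units; beyond the scatter). For the compounds shown here, the earlier steps varied only what sits on the carbonyl and all stayed within the scatter, so this is the first step at this position to go beyond it, and it comes when the carbonyl itself gives way to phenylsulfonyl, which also brings a six-membered aromatic ring of carbon only and more heavy atoms than any of the groups it replaces. No measurement at hand says which part of this exchange accounts for the lower number.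

As far as these compounds go, whether the lower number goes with the sulfonyl or with the phenyl ring stays open, since a benzoyl group would carry the ring without the sulfonyl and a methylsulfonyl group the sulfonyl without the ring. Also open, from the compounds shown here alone, is whether any group on this nitrogen, such as a simple alkyl chain or an acyl group carrying an amine, would lift the read-out above the level shared by compound 1, compound 2 and compound 3.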